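The source may hold more compounds than are shown below. What is called first, only, known or untested is meant among the compounds shown, and "the series" means these compounds.

The compounds share one core. Compound 1 `CCOC(=O)c1ccc2oc(N3CCN(C)CC3)nc2c1` carries an ethoxycarbonyl group on the aromatic ring of that core. In a functional assay on ileum (strain Hartley) for agonist activity at 5-hydroxytryptamine receptor 3A (Cavia porcellus) (a lower number here means a less potent compound, a higher number a more potent compound, by a factor of ten per unit of this negative logarithm), compound 1 reaches only a limit of the assay, < 4, which is the limit of < 4 in this assay, at which 1 of the 3 values shown sits. Two other members of the series give numbers: compound 2 `Cc1cc(Cl)c2oc(N3CCN(C)CC3)nc2c1` gives 6.22 in this assay, and compound 3 `CCc1cccc2nc(N3CCN(C)CC3)oc12` gives 5.48. Compound 1 therefore stands at the bottom of what has been measured so far.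

Compound 4 `CN1CCN(c2nc3cc(N)ccc3o2)CC1` has not yet been tested. It differs from compound 1 in one place: amino in place of ethoxycarbonyl on an aromatic carbon. Going by the values given here, no pair of measured compounds that differ in a single place is available to calibrate such an exchange, so the expectation rests only on where the three measured compounds stand. An upward step from compound 1 to compound 4 is expected, a number at least 1.00 log units higher from compound 1 to compound 4 (beyond the scatter), beyond the usual scatter, because compound 2 gives 6.22 and compound 3 gives 5.48 on the same core. Compound 4 is accordingly expected to give about 5 in this assay, in a range from 4 to 6.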

Compound 4, negative logarithm of the half-maximal effective concentration: 4.97
Estimate against measurement, compound 4: 0.03 log units above; the range from low to high includes it.
By their numbers in this assay, from the lowest: compound 4; then compound 3; then compound 2. At a limit, below all of these: compound 1.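

The exchange gives the series its first measured change in a single place: in this assay, amino in place of ethoxycarbonyl on this aromatic carbon gives a number at least 0.97 log units higher from compound 1 to compound 4 (beyond the scatter). The position therefore does not hold the compounds at the limit of the assay, since a measurable number appears once the ethoxycarbonyl group has left. The true size of the step stays unknown, and only its lower bound can be read, because compound 1 stands at a limit rather than at a number: the limit of < 4 in this assay, at which 1 of the 4 values shown sits.

The compounds shown do not separate what the departure of ethoxycarbonyl contributes from what the arrival of amino contributes, as the unsubstituted carbon is not among them. As far as these compounds go, it also remains open how a carboxylic acid, a methoxy group or an acetamide at this position would compare with amino.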